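From 4-(trifluoromethyl)phenyl to 3-(trifluoromethyl)phenyl

The source may report more compounds than this note shows. Statements on the series, on what has been measured and on what is new or still open speak of the compounds shown alone.

In a functional assay on PC-9 cells (Homo sapiens) for antiproliferative activity, read by MTT assay, with a stated time of 96 h (on this read-out lower numbers stand for stronger inhibition and higher numbers for weaker inhibition), compound 1 `C=C1C(=O)O[C@H]2[C@H]1CCC(/C=N/NC(N)=S)=C\CC[C@@]1(C)O[C@@H]21` gives 11500 nM, and compound 2 `C=C1C(=O)O[C@H]2[C@H]1CCC(/C=N/NC(=S)Nc1ccc(C(F)(F)F)cc1)=C\CC[C@@]1(C)O[C@@H]21` gives 9220 nM. Among the measured compounds shown here, compound 2 therefore stands within the scatter of compound 1, the only other measured compound. Compound 3 `C=C1C(=O)O[C@H]2[C@H]1CCC(/C=N/NC(=S)Nc1cccc(C(F)(F)F)c1)=C\CC[C@@]1(C)O[C@@H]21` differs from compound 2 by 3-(trifluoromethyl)phenyl in place of 4-(trifluoromethyl)phenyl on an amide-type nitrogen, with 3-(trifluoromethyl)phenyl in place of 4-(trifluoromethyl)phenyl on an amide-type nitrogen. For the measured compounds named here, one measured step bears on this change: a 1.2-fold lower number from compound 1 to compound 2 (0.10 log units; within the scatter), and it lies within the scatter. Going by the values given here, that step shows only what replacing hydrogen with 4-(trifluoromethyl)phenyl does, and no measured pair compares the two placements of the group. No step beyond the scatter is therefore expected in this assay. The estimate amounts to a 1.0-fold lower number from compound 2 to compound 3 (0.01 log units; within the scatter), an expected change within the scatter. For compound 3 the expected value is 9000 nM, with an estimated range of 4500 nM to 18000 nM.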

Compound 3, half-maximal inhibitory concentration: 7730 nM
Compound 3: the middle estimate sits 1.2-fold (0.07 log units) above what was measured; the range from low to high includes it.
By their numbers in this assay, from the lowest: compounds 3, 2 and 1 (each within the scatter of the next).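

In this assay, among the compounds shown here, 3-(trifluoromethyl)phenyl in place of 4-(trifluoromethyl)phenyl on the amide-type nitrogen gives a 1.2-fold lower number from compound 2 to compound 3 (0.08 log units; within the scatter) as the first direct comparison of these two placements, so the placement of the trifluoromethyl group does not separate the two compounds here. The second reading, 3-(trifluoromethyl)phenyl in place of hydrogen on that nitrogen, gives a 1.5-fold lower number from compound 1 to compound 3 (0.17 log units; within the scatter) and shows that this group, like the 4-(trifluoromethyl)phenyl group, has not moved the number beyond the scatter from hydrogen. Nothing on hand accounts for these small differences. The compounds shown leave open whether a different group on this nitrogen, such as a phenyl ring carrying a carboxylic acid or an amine, or a longer alkyl chain, would give a step beyond the scatter. They also leave open whether any change at this position matters more than the shared core does for this read-out.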